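Thiazoline-to-oxazoline swap on the sulfonylmethyl arm

The source may hold more compounds than are shown below. What is called first, only, known or untested is meant among the compounds shown, and "the series" means these compounds.

Measured so far:
compound 1 `O=S(=O)(CC1=NCCS1)C1C(c2ccccc2)=NOC1c1ccccc1` — "not active" (no number reported)
compound 2 `COc1ccc(-c2noc(-c3ccc(C)cc3)c2S(=O)(=O)CC2=NCCS2)cc1` — "not active" (no number reported)
compound 3 `COc1ccc(-c2noc(-c3ccc(C)cc3)c2S(=O)(=O)CC2=NCCO2)cc1` — 73%

In a functional assay, read by Griess assay, with a stated time of 150 min, tested at 75 ug/mL (a lower number here means a weaker effect, a higher number a stronger effect of the compound at the concentration tested), compound 1 gives "not active" (no number reported), so no single number stands for it. Compound 2 likewise gives "not active" (no number reported). Compound 3 carries the oxazoline on the same core as compound 2. In this assay compound 3 gives 73%. Compound 4 `O=S(=O)(CC1=NCCO1)C1C(c2ccccc2)=NOC1c1ccccc1` differs from compound 1 by a group of 5 heavy atoms (3 carbon, 1 nitrogen, 1 oxygen; one five-membered non-aromatic ring with 2 hetero atoms) in place of a group of 5 heavy atoms (3 carbon, 1 nitrogen, 1 sulfur; one five-membered non-aromatic ring with 2 hetero atoms), on a saturated chain carbon bound to a sulfonyl sulfur. Among the compounds with values here, no step between measured compounds exists for this pair. On the showing of compound 2 and compound 3, a gain in this assay beyond the scatter is expected, though compound 1 sits on a different core and the outcome is uncertain. Compound 4 is estimated at 40%, within 5% to 75%.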

Compound 4, a percentage reported as activity, at one concentration (the size of the read-out at that concentration, not a potency): 57.2%
Estimate against measurement, compound 4: 17.2 percentage points below; measured number inside the range.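

In this assay, within the data shown here, compound 1 gives "not active" (no number reported), so no step to compound 4 can be read. The compounds shown leave open how much the ring exchange alone changes the read-out on this core. No evidence bears on this result.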